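Nitrophenyl for chlorophenyl repeated on a second core

The compounds below may be only part of what the source reports. "The series", "measured", "known", "first", "only" and "open" are said of these compounds alone.

Compound 1 `CC1=C(C(=O)Nc2ccccc2Cl)C(c2cn(-c3ccccc3)nc2-c2ccccc2)NC(=O)N1` and compound 2 `CC1=C(C(=O)Nc2ccccc2Cl)C(c2cn(-c3ccccc3)nc2-c2ccccc2)NC(=S)N1` share most of their structure; the difference between the two cores is not broken down here. In a functional assay on MCF7 cells (Homo sapiens) for inhibition, read by sulforhodamine B assay, with a stated time of 24 h (on this read-out higher numbers stand for weaker inhibition of growth and lower numbers for stronger inhibition of growth), compound 1 gives 66600 nM and compound 2 gives 68800 nM, two numbers that lie within the scatter of each other. Compound 3 `CC1=C(C(=O)Nc2ccc([N+](=O)[O-])cc2)C(c2cn(-c3ccccc3)nc2-c2ccccc2)NC(=O)N1` carries the change 4-nitrophenyl in place of 2-chlorophenyl on an amide-type nitrogen relative to compound 1; in this assay compound 3 gives 35500 nM, which amounts to a 1.9-fold lower number from compound 1 to compound 3 (0.27 log units; within the scatter). Compound 4 `CC1=C(C(=O)Nc2ccc([N+](=O)[O-])cc2)C(c2cn(-c3ccccc3)nc2-c2ccccc2)NC(=S)N1` is the unmeasured partner, differing from compound 2 by 4-nitrophenyl in place of 2-chlorophenyl on an amide-type nitrogen, the same change at the same place as the one already measured. Given the measured step of a 1.9-fold lower number from compound 1 to compound 3 (0.27 log units; within the scatter) and compound 2 standing at 68800 nM, a step of about the same size is expected for the second core. The expected step in this assay is a 1.9-fold lower number from compound 2 to compound 4 (0.27 log units; within the scatter), resting on that one measured instance alone. Compound 4 is accordingly estimated at 37000 nM, with a range from 20000 nM to 80000 nM, a range that still overlaps the usual scatter around compound 2.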

Compound 4, concentration for 50% growth inhibition: 41400 nM
The estimate for compound 4 lay 1.1-fold (0.05 log units) below the measured number; measured number inside the range.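

In this assay, 4-nitrophenyl in place of 2-chlorophenyl on an amide-type nitrogen gives a 1.7-fold lower number from compound 2 to compound 4 (0.22 log units; within the scatter), and the two cores agree on this change: the same change on two cores in this assay, a 1.9-fold lower number (0.27 log units; within the scatter) from compound 1 to compound 3 and a 1.7-fold lower number (0.22 log units; within the scatter) from compound 2 to compound 4, 1.1-fold (0.05 log units) apart, within the scatter of two such steps. As far as two pairs can show, the change carries from the core of compound 1 to the core of compound 2 with no sign of a different outcome. This does not show that the change itself alters growth inhibition, as each step on its own stays within the scatter, and two pairs set no rule for other cores or other groups.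

As far as these compounds go, it remains open whether a different group on the amide-type nitrogen, such as a phenyl ring bearing an amine or a carboxylic acid, or a longer chain, would give a step beyond the scatter. Also open, from the compounds shown here alone, is how such a group would read on the cores of compound 1 and compound 2, and whether those two cores would still agree.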